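Swapping an amine-bearing side chain for a hydroxyethyl group

The compounds below may be only part of what the source reports. "The series", "measured", "known", "first", "only" and "open" are said of these compounds alone.

Measured so far:
- compound 1, `CCOC(=O)CCO/N=C(/c1ccc(OC)c(OC)c1OC)c1cccc2ccccc12`: 19600 nM
- compound 2, `COc1ccc(C(O)(C/C=C\c2ccccc2)c2cccc3ccccc23)c(OC)c1OC`: 17600 nM
- compound 3, `COc1ccc(C(c2ccc(OC(C)CN(C)C)cc2)c2cccc3ccccc23)c(OC)c1OC`: 11400 nM

All three compounds were tested in a functional assay on A549 cells (Homo sapiens) for inhibition, read by sulforhodamine B assay, with a stated time of 48 h; on this read-out lower numbers stand for stronger inhibition and higher numbers for weaker inhibition. Compound 1 gives 19600 nM in this assay. Compound 2 gives 17600 nM. Compound 3 gives 11400 nM, the lowest of the three numbers, but its gaps to compound 2 and to compound 1 both fall within the usual scatter of repeated measurements, so the three compounds cannot be told apart on these numbers alone.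

Compound 4, `COc1ccc(C(c2ccc(OCCO)cc2)c2cccc3ccccc23)c(OC)c1OC`, has not yet been measured. It differs from compound 3 at one place: 2-hydroxyethyl in place of 1-((dimethylamino)methyl)ethyl on an oxygen on an aromatic ring. Within the data shown here, no pair of measured compounds shows the effect of such a change, so there is no measured step to lean on. The three measured compounds sit close together despite quite different side groups, and the change here is modest in size. Compound 4 is therefore expected to land near compound 3, with a step of a 1.4-fold higher number from compound 3 to compound 4 (0.15 log units; within the scatter) that stays within the scatter. The estimate for compound 4 in this assay is 16000 nM, with a range from 5000 nM to 50000 nM.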

Compound 4, half-maximal inhibitory concentration: > 20000 nM
Compound 4 gave a limit, no number (the forecaster's own chance of this, stated with the estimate: 10%); middle value at least 1.2-fold (0.09 log units) away from the limit.
By their numbers in this assay, from the lowest: compounds 3, 2 and 1 (each within the scatter of the next). At a limit, above all of these: compound 4.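

In this assay, compound 4 gives a limit rather than a number: > 20000 nM. Among these compounds, this is the first measured step at this place, on an oxygen on an aromatic ring, and replacing 1-((dimethylamino)methyl)ethyl with 2-hydroxyethyl gives an at least 1.7-fold higher number from compound 3 to compound 4 (0.24 log units; that floor lies within the scatter). The step is only a floor, so it shows no change beyond the scatter and sets no upper bound on the gap, and the final number for compound 4 remains unknown, as the reading is capped: the limit of > 20000 nM in this assay, at which 1 of the 4 values shown sits.

Two things change at once in this swap, since the nitrogen-bearing branched chain leaves and a shorter chain ending in a hydroxyl enters, so the step cannot say which of them matters. A 2-(dimethylamino)ethyl chain, a longer chain ending in a hydroxyl, or a carboxylic acid on the same oxygen would help separate the role of the amine from that of the chain, and a measured number for compound 4 in place of its limit would be needed to fix the true size of the step.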